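Triazolylthio naphthol amides: styryl replacement in compound 4

The compounds below may be only part of what the source reports. "The series", "measured", "known", "first", "only" and "open" are said of these compounds alone.

Measured so far:
compound 1, `O=C(Nc1cc(Sc2ncn[nH]2)c(O)c2ccccc12)c1ccc2ccccc2c1`, 41.6%
compound 2, `COc1ccc(/C=C/C(=O)Nc2cc(Sc3ncn[nH]3)c(O)c3ccccc23)cc1OC`, 31.7%
compound 3, `O=C(Nc1cc(Sc2ncn[nH]2)c(O)c2ccccc12)c1cccc(Cl)c1`, 46%

In an assay on isolated protein for inhibition of RAC-alpha serine/threonine-protein kinase (Homo sapiens), read by fluorescence, with a stated time of 30 min, tested at 10 uM (a lower number here means less inhibition, a higher number more inhibition at the concentration tested (going by the name of the read-out)), compound 3 gives the highest of the three numbers. Going by the values given here, compound 1 lies nearest to it, and the single one-place step on record, a number 4.4 percentage points higher from compound 1 to compound 3 (within the scatter), is within the scatter, so the two cannot be ordered. Compound 2 lies furthest from compound 3, and the gap between their values is beyond the scatter.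

Compound 4, `O=C(/C=C/c1ccccc1)Nc1cc(Sc2ncn[nH]2)c(O)c2ccccc12`, is not yet measured in this assay. Its difference from compound 3 is 2-phenylethenyl in place of 3-chlorophenyl on a carbonyl carbon.

Among the compounds with values here, no measured step bears directly on this change. Within the data shown here, the one step available, from compound 1 to compound 3, swaps one aromatic group for another on the same carbonyl carbon and is within the scatter. Among the measured compounds shown here, compound 2 is the only measured compound carrying a double bond outside aromatic rings at that position, and it gives the lowest number of the three; compound 4 shares that feature but lacks the two methoxy groups of compound 2. On this basis a step downward of modest size, a number 10 percentage points lower from compound 3 to compound 4 (within the scatter), is expected, though it may well stay within the scatter. For compound 4 the expected inhibition is 36%, with a range from 22% to 50%.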

Compound 4, a percentage reported as inhibition, at one concentration (the size of the read-out at that concentration, not a potency): 26.2%
Estimate against measurement, compound 4: 9.8 percentage points above; the range from low to high includes it.
By their numbers in this assay, from the lowest: compounds 4, 2, 1 and 3 (each within the scatter of the next, the first and the last beyond it).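

In this assay this carbonyl carbon now shows steps beyond the scatter, with 2-phenylethenyl in place of 3-chlorophenyl read as a number 19.8 percentage points lower from compound 3 to compound 4 (beyond the scatter) and in place of naphthalen-2-yl read as a number 15.4 percentage points lower from compound 1 to compound 4 (beyond the scatter) against the earlier exchange of the two aromatic groups, a number 4.4 percentage points higher from compound 1 to compound 3 (within the scatter) and so unresolved. At the far end of the chain, phenyl in place of 3,4-dimethoxyphenyl gives a number 5.5 percentage points lower from compound 2 to compound 4 (within the scatter) and leaves the two compounds unordered, so the two methoxy groups produce no difference that this read-out can resolve. No measurement on hand accounts for the lower numbers seen with 2-phenylethenyl at this position.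

The compounds shown leave open whether the step follows the double bond itself or the longer link to the phenyl ring, a question that a saturated 2-phenylethyl group on the same carbonyl carbon would address. Also open, from the compounds shown here alone, is whether an amine or a carboxylic acid on the phenyl ring of 2-phenylethenyl would shift the number in this assay at all.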